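The source may report more compounds than this note shows. Statements on the series, on what has been measured and on what is new or still open speak of the compounds shown alone.

Of the compounds shown here, three from this series have been measured in an ADME assay on MT4 cells (Homo sapiens) for cytotoxicity, read by MTT assay, with a stated time of 5 days; on this read-out lower numbers stand for higher toxicity in this test and higher numbers for lower toxicity in this test. Compound 1 `Cc1cc(C)c(Oc2cc(NCCn3ccc(=O)[nH]c3=O)nc(Cl)n2)c(C)c1` gives 76400 nM in this assay. Compound 2 `Cc1cc(C#N)cc(C)c1Oc1ccnc(NCCn2ccc(=O)[nH]c2=O)n1` gives 35800 nM, and compound 3 `Cc1cc(C#N)cc(C)c1Oc1cc(Cl)nc(NCCn2ccc(=O)[nH]c2=O)n1` gives 20600 nM, the lowest of the three numbers. Among the measured compounds shown here, the only single-point step so far is a 1.7-fold lower number from compound 2 to compound 3 (0.24 log units; within the scatter). For the measured compounds named here, compound 3 lies within the scatter of compound 2, while compound 1 stands at a clearly higher number, beyond the scatter, though no single-point step connects compound 1 to compound 3.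

Compound 4 `Cc1cc(C)c(Oc2cc(Cl)nc(NCCn3ccc(=O)[nH]c3=O)n2)c(C)c1` differs from compound 3 by methyl in place of cyano on an aromatic carbon. Going by the values given here, none of the measured steps involves this exchange, so there is no direct precedent in this assay. Among the compounds with values here, the one measured step, from compound 2 to compound 3, concerns a different position and is within the scatter, which suggests modest effects from single changes here. Compound 1 carries the same methyl group that enters in compound 4, and its number in this assay is higher than that of compound 3, but the two cores are not the same. The author therefore expects compound 4 to show a step of a 1.7-fold higher number from compound 3 to compound 4 (0.23 log units; within the scatter), likely toward a higher number but not confidently beyond the scatter. Compound 4 is estimated at 35000 nM, between 12000 nM and 100000 nM.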

Compound 4, half-maximal cytotoxic concentration: 44100 nM
Estimate against measurement, compound 4: 1.3-fold (0.10 log units) below; low and high end bracket the measured number.
By their numbers in this assay, from the lowest: compounds 3, 2, 4 and 1 (each within the scatter of the next, the first and the last beyond it).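

In this assay, among the compounds shown here, the exchange of cyano for methyl on the aromatic carbon para to a large group gives a 2.1-fold higher number from compound 3 to compound 4 (0.33 log units; beyond the scatter) and is the first single-point change here to pass the scatter. For the compounds shown here, the only earlier step, chloro in place of hydrogen on the other aromatic ring, gave a 1.7-fold lower number from compound 2 to compound 3 (0.24 log units; within the scatter) and so showed no clear change, whereas this place on the six-membered ring of carbon only does move the number, if modestly, toward lower toxicity in this test. Nothing available explains why the number moves when the nitrile gives way to the methyl group.

Going by these compounds, the exchange has been read on a single background carrying chloro, so it remains open whether methyl in place of cyano gives a similar step on the core of compound 2, which has hydrogen where compound 3 has chloro. On these data alone, it also remains open how this place would read with hydrogen, an amine, a carboxylic acid or a longer chain such as ethyl, and so whether the number follows any order across groups or merely differs between these two.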